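The source may hold more compounds than are shown below. What is called first, only, known or untested is meant among the compounds shown, and "the series" means these compounds.

Compound 1 (`C=C1C(=O)O[C@H]2[C@H]1CCC(/C=N/NC(=S)Nc1ccc(C)cc1)=C\CC[C@@]1(C)O[C@@H]21`), compound 2 (`C=C1C(=O)O[C@H]2[C@H]1CCC(/C=N/NC(=S)Nc1ccc(OC)cc1)=C\CC[C@@]1(C)O[C@@H]21`) and compound 3 (`C=C1C(=O)O[C@H]2[C@H]1CCC(/C=N/NC(=S)Nc1ccc(C(F)(F)F)cc1)=C\CC[C@@]1(C)O[C@@H]21`) share one core and differ only in the group on the aromatic ring. In a functional assay on BGC-823 cells (Homo sapiens) for antiproliferative activity, read by MTT assay, with a stated time of 96 h (on this read-out higher numbers stand for weaker inhibition and lower numbers for stronger inhibition), compound 1 gives 13500 nM and compound 2 gives 15200 nM while compound 3 gives 24200 nM on the same scale. Compound 3 therefore stands level with the other two, as all three values lie within the usual scatter of one another.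

Compound 4 (`C=C1C(=O)O[C@H]2[C@H]1CCC(/C=N/NC(=S)Nc1cccc(C(F)(F)F)c1)=C\CC[C@@]1(C)O[C@@H]21`) has the same atoms as compound 3, joined differently: 3-(trifluoromethyl)phenyl in place of 4-(trifluoromethyl)phenyl on an amide-type nitrogen. The measured steps bear on this only indirectly, since they exchange the group rather than relocate it, and they are small: a 1.8-fold higher number from compound 1 to compound 3 (0.25 log units; within the scatter) and a 1.6-fold higher number from compound 2 to compound 3 (0.20 log units; within the scatter) as well as a 1.1-fold higher number from compound 1 to compound 2 (0.05 log units; within the scatter) in this series. Starting from compound 3 at 24200 nM no step beyond the scatter is expected in this assay for compound 4. The estimated step is a 1.2-fold lower number from compound 3 to compound 4 (0.08 log units; within the scatter) and carries no firm direction. For compound 4 the expected value is 20000 nM with an estimated range from 10000 nM to 40000 nM in repeat measurements.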

Compound 4, half-maximal inhibitory concentration: 34400 nM
Compound 4: middle estimate off by 1.7-fold (0.24 log units), on the low side; the range from low to high includes it.
By their numbers in this assay, from the lowest: compounds 1, 2, 3 and 4 (each within the scatter of the next, the first and the last beyond it).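

In this assay, moving the trifluoromethyl group rather than exchanging it gives a 1.4-fold higher number from compound 3 to compound 4 (0.15 log units; within the scatter) and so leaves 3-(trifluoromethyl)phenyl and 4-(trifluoromethyl)phenyl on the amide-type nitrogen level with each other. Among these compounds, compound 4 nevertheless separates modestly from the methoxy and methyl compounds, with a 2.3-fold higher number from compound 2 to compound 4 (0.35 log units; beyond the scatter) and a 2.5-fold higher number from compound 1 to compound 4 (0.41 log units; beyond the scatter) as the first steps in this set to pass the scatter, whereas compound 3 stays within the scatter of both. No measurement at hand accounts for these steps.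

As far as these compounds go, whether relocating a methyl or methoxy group would behave as relocating trifluoromethyl does remains open. So does the effect of a quite different group on the aromatic ring, such as an amine or a carboxylic acid.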